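The source may hold more compounds than are shown below. What is called first, only, known or untested is meant among the compounds shown, and "the series" means these compounds.

The account follows compound 1 `O=S(=O)(CCC(F)(Cl)C(F)(F)Cl)c1nc2ccccc2s1` to compound 4 `O=S(=O)(CCC(F)=C(F)F)c1nc2ccccc2s1`, which is still to be measured. In a functional assay on HepG2 cells (Homo sapiens) for cytotoxicity, read by MTT assay, with a stated time of 48 h (a higher number here means a weaker inhibitor, a lower number a stronger inhibitor), compound 1 gives 4500 nM; of the two numbers in hand this is the smaller, though the gap to compound 2 is within the scatter. Compound 2 `O=S(=O)(CCC(F)(Cl)C(F)(F)Cl)c1nc2ccc(Cl)cc2s1` gives 6100 nM in this assay, and the step of a 1.4-fold higher number from compound 1 to compound 2 (0.13 log units; within the scatter) reflects a chloro in place of hydrogen on an aromatic carbon. Compound 3 `FC(F)=C(F)CCSc1ccccn1` is reported in this assay only as a limit, > 120000 nM. That value is the limit of > 120000 nM in this assay, at which 1 of the 3 values shown sits. The change from compound 1 to compound 4 is 1,2,2-trifluoroethenyl in place of 1,2-dichloro-1,2,2-trifluoroethyl on a saturated chain carbon, two bonds along the chain from a sulfonyl sulfur. Within the data shown here, no measured step exchanges this chain end; the one measured step, from compound 1 to compound 2, alters the aromatic ring and stays within the scatter, so it offers no direct guidance. Compound 3 carries the same trifluoroethenyl chain on a different core with a thioether link, and its result is a limit rather than a number. The step of a 2.7-fold higher number from compound 1 to compound 4 (0.43 log units; beyond the scatter) is therefore expected to run towards a weaker inhibitor, somewhat beyond the scatter. Compound 4 is estimated at 12000 nM, within 4000 nM to 40000 nM.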

Compound 4, half-maximal inhibitory concentration: 3710 nM
Compound 4: the middle estimate sits 3.2-fold (0.51 log units) above what was measured; measured number below the stated range.
By their numbers in this assay, from the lowest: compounds 4, 1 and 2 (each within the scatter of the next). At a limit, above all of these: compound 3.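

In this assay, the exchange of the chain end gives a 1.2-fold lower number from compound 1 to compound 4 (0.08 log units; within the scatter), so on a saturated chain carbon, two bonds along the chain from a sulfonyl sulfur, 1,2,2-trifluoroethenyl and 1,2-dichloro-1,2,2-trifluoroethyl cannot be told apart. Among these compounds, the only earlier step altered the aromatic ring, whereas this one shows that the chain end can lose its chlorine and gain a double bond outside aromatic rings without a change beyond the scatter. Nothing shown gives a cause for this result.

The compounds shown leave open whether this place would accept a quite different chain end, such as an amine, a carboxylic acid or a longer chain. They also leave open how a thioether link in place of the sulfonyl would read on the shared core.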